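The source may report more compounds than this note shows. Statements on the series, on what has been measured and on what is new or still open speak of the compounds shown alone.

Measured in an ADME assay on HCT-116 cells (Homo sapiens) for cytotoxicity, read by CellTiter-Glo, with a stated time of 72 h (a lower number here means a stronger inhibitor, a higher number a weaker inhibitor), each value a limit:
- compound 1 `CCCOc1ccc(S(=O)(=O)N2CCC(N3CCC(C)CC3)CC2)cc1`: > 5000 nM
- compound 2 `CC1CCN(C2CCN(S(=O)(=O)c3ccc(-c4ccc(Cl)cc4)cc3)CC2)CC1`: > 5000 nM
- compound 3 `CC1CCN(C2CCN(S(=O)(=O)c3ccc(OCc4ccccc4)cc3)CC2)CC1`: > 5000 nM

Compound 3 stands only at a limit, with no number to its name, and the series as a whole offers just (the limit of > 5000 nM in this assay, at which 3 of the 3 values shown sit). Compound 4 `CCCCOc1ccc(S(=O)(=O)N2CCC(N3CCC(C)CC3)CC2)cc1` has propyl in place of phenyl on a saturated chain carbon bound to an oxygen on an aromatic ring, that is, butoxy for benzyloxy: propyl in place of phenyl on a saturated chain carbon bound to an oxygen on an aromatic ring. Within the data shown here, two measured steps bear on this change: a step that the two limits leave unreadable from compound 1 to compound 3, at the same place, and a step that the two limits leave unreadable from compound 2 to compound 3. Neither has a readable size, so no particular direction can be drawn from them. The expected change is no more than the scatter, and the estimate means a step that the limit leaves unreadable from compound 3 to compound 4. Compound 4 is expected to lie near 8000 nM, within an estimated range of 3000 nM to 20000 nM.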

Compound 4, half-maximal inhibitory concentration: > 5000 nM
Compound 4 gave a limit, no number (the forecaster's own chance of this, stated with the estimate: 90%); the middle value is on the limit's open side.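

No step among compound 1, compound 2, compound 3 and compound 4 can be read, since each value is only a limit: the limit of > 5000 nM in this assay, at which 4 of the 4 values shown sit.

As far as these compounds go, whether any of these changes moves the value in this assay at all, and by how much, stays open.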